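A few compounds are considered here, and "the series" means these few. Any claim that something is new, unique, unknown or untested is made for them only; others in the source may bear on it.

In an in vitro ADME assay on microsomes from liver (Mus musculus) for pharmacokinetics, read by LC-MS, with a stated time of 10 min, tested at 1 uM (on this read-out lower numbers stand for slow clearance and higher numbers for fast clearance), compound 1 (`CN1C[C@H](C(=O)Nc2ccccc2)[C@@H](c2ccc(/C=C/C(=O)Nc3ccccc3N)cc2)C1`) gives 67 mL/min/kg and compound 2 (`CN1C[C@H](C(=O)Nc2cccc(F)c2)[C@@H](c2ccc(/C=C/C(=O)Nc3ccccc3N)cc2)C1`) gives 56 mL/min/kg, so these two values lie within the scatter of each other. Compound 3 (`CN1C[C@H](C(=O)Nc2ccc(F)c(Cl)c2)[C@@H](c2ccc(/C=C/C(=O)Nc3ccccc3N)cc2)C1`) differs from compound 2 as follows: 3-chloro-4-fluorophenyl in place of 3-fluorophenyl on an amide-type nitrogen. In words, this is 3-chloro-4-fluorophenyl in place of 3-fluorophenyl on an amide-type nitrogen. Within the data shown here, one measured step bears on this change: fluoro in place of hydrogen on an aromatic carbon, in the group on that same nitrogen, gave a 1.2-fold lower number from compound 1 to compound 2 (0.08 log units; within the scatter). Among the measured compounds shown here, that step is small and within the scatter, although no measured compound yet carries chlorine, so the evidence is thin. No shift beyond the scatter is expected, and the estimated step is a 1.1-fold lower number from compound 2 to compound 3 (0.05 log units; within the scatter). For compound 3, the estimated clearance is 50 mL/min/kg, with an expected range of 25 mL/min/kg to 95 mL/min/kg.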

Compound 3, clearance: 34 mL/min/kg
Estimate against measurement, compound 3: 1.5-fold (0.17 log units) above; low and high end bracket the measured number.
By their numbers in this assay, from the lowest: compounds 3, 2 and 1 (each within the scatter of the next).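

Among these compounds, compound 3 is the only compound here that carries chlorine, and on the group on the amide-type nitrogen in this assay the change gives a 1.6-fold lower number from compound 2 to compound 3 (0.22 log units; within the scatter) and, measured from the unsubstituted phenyl, a 2.0-fold lower number from compound 1 to compound 3 (0.29 log units; within the scatter) as well. Both steps lie within the scatter, so phenyl, 3-fluorophenyl and 3-chloro-4-fluorophenyl cannot be told apart at this position, even with two halogens on the ring. No measurement at hand offers an explanation for these numbers.

From the compounds shown here alone, it remains open whether a group of another kind on this nitrogen, such as a pyridine ring, a carboxylic acid or an amine-bearing chain, would shift clearance beyond the scatter. The separate contributions of the chloro and 4-fluoro substituents also remain unresolved, as does the effect of replacing the methyl group on the core's nitrogen.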